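The source may hold more compounds than are shown below. What is called first, only, known or untested is meant among the compounds shown, and "the series" means these compounds.

Measured so far:
compound 1, `Cc1ccc(S(=O)(=O)n2cc(CNCc3cccc(F)c3F)c3ccccc32)cc1` — 46%
compound 2, `O=S(=O)(c1ccc(F)cc1)N(Cc1cccc(F)c1F)Cc1cn(S(=O)(=O)c2ccc(F)cc2)c2ccccc12` — -20%
compound 3, `Cc1ccc(S(=O)(=O)N(Cc2cccc(F)c2F)Cc2cn(S(=O)(=O)c3ccc(F)cc3)c3ccccc23)cc1` — -35%

In a functional assay on 3T3-L1 cells (Mus musculus) for inhibition, with a stated time of 20 min, tested at 20 uM (on this read-out higher numbers stand for more inhibition at the one concentration tested (going by the name of the read-out) and lower numbers for less inhibition), compound 3 stands lowest of the three. Among the measured compounds shown here, its nearest neighbour is compound 2, and the only single step measured, a number 15 percentage points lower from compound 2 to compound 3 (beyond the scatter), concerns methyl in place of fluoro on an aromatic carbon. For the measured compounds named here, compound 1 sits far above both, and it is the one compound carrying a free amine rather than a second sulfonyl group on that nitrogen.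

Compound 4, `O=S(=O)(c1ccc(F)cc1)n1cc(CNCc2cccc(F)c2F)c2ccccc21`, is reached from compound 3 by hydrogen in place of (4-methylphenyl)sulfonyl on an amine nitrogen. Going by the values given here, no measured step follows this exact change; the step from compound 2 to compound 3 concerns a different position and does not bear on it directly. What the numbers show is that compound 1, with the free amine, gives 46% in this assay, while compound 2 gives -20% and compound 3 gives -35%, both carrying the tertiary sulfonamide. A large rise is therefore expected, a number 77 percentage points higher from compound 3 to compound 4 (beyond the scatter), landing compound 4 near compound 1. Compound 4 is estimated at 42%, in a range from 18% to 66%.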

Compound 4, a percentage reported as inhibition, at one concentration (the size of the read-out at that concentration, not a potency): 21%
Compound 4: the middle estimate sits 21 percentage points above what was measured; measured number inside the range.
By their numbers in this assay, from the lowest: compound 3; then compound 2; then compound 4; then compound 1.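

Putting hydrogen on the amine nitrogen is now measured directly against both tertiary sulfonamides: replacing (4-methylphenyl)sulfonyl gives a number 56 percentage points higher from compound 3 to compound 4 (beyond the scatter), and replacing (4-fluorophenyl)sulfonyl gives a number 41 percentage points higher from compound 2 to compound 4 (beyond the scatter). The free amine does not settle the number alone, however, since fluoro in place of methyl on an aromatic carbon, with the amine free in both compounds, gives a number 25 percentage points lower from compound 1 to compound 4 (beyond the scatter). The exchange of fluoro for methyl also runs in opposite directions on the two cores, so its result cannot be carried from one to the other: the same change on two cores in this assay, a number 15 percentage points lower (beyond the scatter) from compound 2 to compound 3 and a number 25 percentage points higher (beyond the scatter) from compound 4 to compound 1, 40 percentage points apart, beyond the scatter of two such steps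

The compounds shown leave open how an acetyl or a methyl group on this amine nitrogen would compare with hydrogen. They also leave open how a carboxylic acid in place of the methyl or fluoro on that aromatic ring would read.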